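This account rests on a few compounds, and the source may have more. Where it says the series, first, only, none or still open, it means among the compounds named here.

Three compounds share one core and differ only in the aromatic ring at the far end of the unsaturated amide chain. In a functional assay on B16-F10 cells (Mus musculus) for inhibition, read by MTT assay, with a stated time of 48 h (a higher number here means a weaker inhibitor, a lower number a stronger inhibitor), compound 1 `COc1ccc(/C=C/C(=O)Nc2ccc3ncnc(Nc4cccc(Br)c4)c3c2)cc1` gives 1.24 ug/mL, compound 2 `COc1ccccc1/C=C/C(=O)Nc1ccc2ncnc(Nc3cccc(Br)c3)c2c1` gives 1.28 ug/mL, and compound 3 `Cc1ccc(/C=C/C(=O)Nc2ccc3ncnc(Nc4cccc(Br)c4)c3c2)cc1` gives 1.39 ug/mL. Compound 3 cannot be told apart from the other two, since the steps of a 1.1-fold higher number from compound 1 to compound 3 (0.05 log units; within the scatter) and a 1.1-fold higher number from compound 2 to compound 3 (0.04 log units; within the scatter) both lie within the scatter. Compound 4 `O=C(/C=C/c1ccc([N+](=O)[O-])cc1)Nc1ccc2ncnc(Nc3cccc(Br)c3)c2c1` carries nitro in place of methyl on an aromatic carbon. Among the compounds with values here, those two steps are the only ones that touch this ring, and neither moved the number beyond the scatter, although a nitro group appears in none of the measured compounds. The step from compound 3 to compound 4 is therefore expected to be a 1.1-fold lower number from compound 3 to compound 4 (0.03 log units; within the scatter), with no direction beyond the scatter. Compound 4 is estimated at 1.3 ug/mL, between 0.6 ug/mL and 2.8 ug/mL.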

Compound 4, half-maximal inhibitory concentration: 0.982 ug/mL
Compound 4: middle estimate off by 1.3-fold (0.12 log units), on the high side; measured number inside the range.
By their numbers in this assay, from the lowest: compounds 4, 1, 2 and 3 (each within the scatter of the next).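

In this assay the nitro group, with its two hydrogen-bond acceptors where methyl has none, gives a 1.4-fold lower number from compound 3 to compound 4 (0.15 log units; within the scatter). Against the two methoxy compounds the result is a 1.3-fold lower number from compound 2 to compound 4 (0.12 log units; within the scatter) and a 1.3-fold lower number from compound 1 to compound 4 (0.10 log units; within the scatter), so on these compounds a larger nitro group at this ring position shifts the number no more than methyl or methoxy did. No measurement here bears on the reason for this result.

On these data alone, whether an amine or a carboxylic acid on this aromatic carbon would give a step beyond the scatter remains open. So does the effect of a longer chain there.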